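The compounds below may be only part of what the source reports. "The series", "measured", "known", "first", "only" and "open" are said of these compounds alone.

Measured so far:
compound 1, `O=C(O)CS(=O)(=O)c1ccc(OCc2cccc(-c3ccccc3F)c2)cc1` — 257 nM
compound 2, `O=C(O)CS(=O)(=O)c1cccc(OCc2ccc(-c3ccccc3)cc2)c1` — > 1000 nM

Of the compounds shown here, two have been tested in a functional assay on CHO cells for agonist activity at Free fatty acid receptor 1 (Homo sapiens), read by FLIPR and calcium flux; a higher number here means that more compound is needed for the effect, a lower number that less compound is needed. Compound 1 gives 257 nM there. Compound 2 returns only > 1000 nM, which is a limit of the assay rather than a number. So compound 2 stands at the upper edge of what the assay can report: of the two values, one sits at the limit (the limit of > 1000 nM in this assay, at which 1 of the 2 values shown sits), and compound 2 is that one.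

Compound 3, `Cc1ccccc1-c1ccc(COc2cccc(S(=O)(=O)CC(=O)O)c2)cc1`, keeps the core of compound 2 and differs from it in one place: methyl in place of hydrogen on an aromatic carbon, sitting ortho to a large group. Within the data shown here, no measured pair shows this change, so there is nothing to set its size from. Since compound 2 is already at the limit with > 1000 nM, the step is expected to be small and compound 3 is expected to remain weak, most likely again reported as a limit. The estimated step is a step that the limit leaves unreadable from compound 2 to compound 3. Compound 3 is therefore expected near 2000 nM, within a range from 600 nM to 8000 nM.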

Compound 3, half-maximal effective concentration in the Free fatty acid receptor 1 assay: > 1000 nM
Compound 3 ended at the assay's limit; the forecaster's own chance of this, stated with the estimate: 60%; the middle value lies beyond the limit too.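

In the Free fatty acid receptor 1 assay, compound 2 gives > 1000 nM, which is a limit of the assay and not a number. In the Free fatty acid receptor 1 assay, compound 3 gives > 1000 nM, which is also a limit of the assay and not a number. No step can be read between them: the limit of > 1000 nM in the Free fatty acid receptor 1 assay, at which 2 of the 3 values shown sit. The compounds shown leave open whether methyl in place of hydrogen on an aromatic carbon changes the response in the Free fatty acid receptor 1 assay at all. In a physicochemical assay for lipophilicity, using the shake flask method, in phosphate buffer, measured as octanol-water partition, with a stated time of 24 h, at pH 7.4, tested at 100 uM (on this read-out lower numbers stand for lower lipophilicity and higher numbers for higher lipophilicity), compound 2 is recorded as "not determined" (no result reported) and compound 3 as "not determined" (no result reported), so no result is reported for either.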